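The compounds below may be only part of what the source reports. "The series", "measured", "known", "first", "only" and "open" are said of these compounds alone.

Measured compounds:
- compound 1, `CCCc1nc(-c2ccccc2)c(CNCCN2CCN(c3ccc(F)cc3)CC2)o1`: 7080 nM
- compound 2, `CCCc1nc(-c2ccccc2)c(CNCCN2CCN(c3cccc(C)c3C)CC2)o1`: 1710 nM

For the measured compounds named here, in an assay on HEK293 cells for inhibition of Voltage-dependent T-type calcium channel subunit alpha-1G (Homo sapiens), read by patch clamp (on this read-out lower numbers stand for stronger inhibition and higher numbers for weaker inhibition), compound 2 stands lowest of the two numbers known; its nearest neighbour, compound 1, lies higher by the step of a 4.1-fold lower number from compound 1 to compound 2 (0.62 log units; beyond the scatter), which exchanged a 4-fluorophenyl for a 2,3-dimethylphenyl on the ring amine nitrogen.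

Compound 3, `CCCc1nc(-c2ccccc2)c(CNCCN2CCN(c3ccccc3)CC2)o1`, differs from compound 2 by phenyl in place of 2,3-dimethylphenyl on an amine nitrogen in a ring. Going by the values given here, only the step from compound 1 to compound 2 bears on this change, and it concerned a different pair of groups, so it is no direct guide. Since phenyl carries neither substituent seen so far, compound 3 is expected to fall between the two measured values, and its estimated step is a 2.0-fold higher number from compound 2 to compound 3 (0.31 log units; beyond the scatter). The estimate for compound 3 in this assay is 3500 nM, within a range from 1500 nM to 8000 nM.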

Compound 3, half-maximal inhibitory concentration: 10300 nM
Beside the measured number, compound 3's estimate is 2.9-fold (0.47 log units) below it; the measured number lies above the stated range.
By their numbers in this assay, from the lowest: compound 2; then compounds 1 and 3 (each within the scatter of the next).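

In this assay, the lower number of compound 2 goes with its 2,3-dimethylphenyl group, since the step to plain phenyl is a 6.0-fold higher number from compound 2 to compound 3 (0.78 log units; beyond the scatter) and undoes all of the earlier difference. The fluoro on the aromatic carbon shows no effect of its own: a 1.5-fold higher number from compound 1 to compound 3 (0.16 log units; within the scatter) is the step for hydrogen in its place. Nothing measured here offers a reason for either step.

On these data alone, whether a single methyl group would be enough remains open, as does whether a chloro or methoxy group on the phenyl would match the 2,3-dimethylphenyl group.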